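Swapping the Amine Group on Compound 2

A few compounds are considered here, and "the series" means these few. Any claim that something is new, unique, unknown or untested is made for them only; others in the source may bear on it.

Measured in a functional assay on UMUC3 cells (Homo sapiens) for antiproliferative activity, read by MTT assay, with a stated time of 72 h; a higher number here means a weaker inhibitor, a lower number a stronger inhibitor:
- Compound 1 `N=C(NC(=N)NC1CCCC1)Nc1ccc(C(F)(F)F)cc1`: 3300 nM
- Compound 2 `CC(C)CNC(=N)NC(=N)Nc1ccc(C(F)(F)F)cc1`: 2000 nM
- Compound 3 `CC(C)NC(=N)NC(=N)Nc1ccc(F)c(F)c1`: 25000 nM

Compound 2 at 2000 nM cannot be told apart from compound 1, while compound 3 reads much higher at 25000 nM. Compound 4 `CCN(C)C(=N)NC(=N)Nc1ccc(C(F)(F)F)cc1` changes one group of compound 2: ethyl(methyl)amino in place of isobutylamino on a carbon with a double bond to nitrogen. Going by the values given here, the one measured step that bears on this is a 1.7-fold lower number from compound 1 to compound 2 (0.22 log units; within the scatter), which also exchanges a group on an amine nitrogen. Among the compounds with values here, no measured step removes a hydrogen-bond donor, so the size of this change remains uncertain. The expected result in this assay is a modest rise, a 1.8-fold higher number from compound 2 to compound 4 (0.24 log units; within the scatter). The estimated value for compound 4 is 3500 nM, with an expected range of 1200 nM to 10000 nM.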

Compound 4, half-maximal inhibitory concentration: 6900 nM
The estimate for compound 4 lay 2.0-fold (0.29 log units) below the measured number, within the range that was stated.
By their numbers in this assay, from the lowest: compounds 2 and 1 (each within the scatter of the next); then compound 4; then compound 3.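

Once ethyl(methyl)amino enters, this assay shows a 3.5-fold higher number from compound 2 to compound 4 (0.54 log units; beyond the scatter) and a 2.1-fold higher number from compound 1 to compound 4 (0.32 log units; beyond the scatter), whereas the earlier exchange on this amine nitrogen stayed within the scatter. Ethyl(methyl)amino has 0 hydrogen-bond donors against 1 for isobutylamino, but also 4 heavy atoms against 5, so this one step cannot separate those two differences. No measurement shown here explains the rise.

Still open, as far as these compounds go, is whether methylamino, which keeps its nitrogen hydrogen on a shorter chain, would stay level with compound 2. Dimethylamino would test the loss of that hydrogen on a smaller group.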